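Aryl swap on the ring nitrogen: compound 3 to compound 4

This account rests on a few compounds, and the source may have more. Where it says the series, first, only, none or still open, it means among the compounds named here.

Three measured analogues share one core and differ only in the aryl group on the ring nitrogen. Compound 1 `COc1cc2ncnc(Nc3ccc(F)c(Br)c3)c2cc1OCCCCC(=O)Nc1ccc(S(N)(=O)=O)cc1` gives 16000 nM in a functional assay on A549 cells (Homo sapiens) for antiproliferative activity, read by MTT assay, with a stated time of 72 h; a higher number here means a weaker inhibitor, a lower number a stronger inhibitor. Compound 3 `COc1ccccc1Nc1ncnc2cc(OC)c(OCCCCC(=O)Nc3ccc(S(N)(=O)=O)cc3)cc12` gives 24100 nM in this assay. Compound 2 `COc1cc2ncnc(Nc3ccc(OC(F)(F)F)cc3)c2cc1OCCCCC(=O)Nc1ccc(S(N)(=O)=O)cc1` reaches only the limit of > 40000 nM in this assay. Of the two numbers, compound 3 holds the higher one, with compound 1 nearest: a 1.5-fold higher number from compound 1 to compound 3 (0.18 log units; within the scatter).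

Compound 4 `COc1cc2ncnc(Nc3ccc(C)cc3)c2cc1OCCCCC(=O)Nc1ccc(S(N)(=O)=O)cc1` differs from compound 3 by 4-methylphenyl in place of 2-methoxyphenyl on a nitrogen on an aromatic ring whose other neighbours are aromatic carbon. All three measured steps exchange the aryl group on that same nitrogen: an at least 2.5-fold higher number from compound 1 to compound 2 (0.39 log units; beyond the scatter), which rests on (the limit of > 40000 nM in this assay, at which 1 of the 3 values shown sits); a 1.5-fold higher number from compound 1 to compound 3 (0.18 log units; within the scatter); an at least 1.6-fold lower number from compound 2 to compound 3 (0.22 log units; that floor lies within the scatter). Only the first passes beyond the scatter.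

Aryl swaps here have moved the number little, so the expected step of a 1.2-fold lower number from compound 3 to compound 4 (0.08 log units; within the scatter) is small, with no direction beyond the scatter. Compound 4 is therefore expected near 20000 nM, between 8000 nM and 50000 nM.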

Compound 4, half-maximal inhibitory concentration: > 40000 nM
Compound 4: no number, only a limit (the forecaster's own chance of this, stated with the estimate: 25%); middle value at least 2.0-fold (0.30 log units) from the limit.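

Exchanging 3-bromo-4-fluorophenyl for 4-methylphenyl gives an at least 2.5-fold higher number from compound 1 to compound 4 (0.39 log units; beyond the scatter), the second aryl swap on this nitrogen in this assay to pass beyond the scatter. Exchanging 2-methoxyphenyl for 4-methylphenyl gives an at least 1.6-fold higher number from compound 3 to compound 4 (0.22 log units; that floor lies within the scatter), so compound 3 and compound 4 cannot be separated, and the step between compound 2 and compound 4 cannot be read. Aryl swaps at this position now end as often in a limit as in a number: the limit of > 40000 nM in this assay, at which 2 of the 4 values shown sit.

On these data alone, how far compound 2 and compound 4 lie past that limit remains open. Also open, as far as these compounds go, is whether a phenyl group carrying an amine or a carboxylic acid on this nitrogen would clearly improve on compound 1, at 16000 nM.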